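The compounds below may be only part of what the source reports. "The series", "measured", "known", "first", "only" and "open" are said of these compounds alone.

Compound 1 `COc1ccc(-c2nc3cc(C(F)(F)F)ccc3[nH]2)c(OC)c1`, compound 2 `COc1ccc(-c2nc3cc(C(F)(F)F)ccc3[nH]2)cc1` and compound 3 `COc1ccc(-c2nc3cc(Cl)c(Cl)cc3[nH]2)c(N)c1` share one core and differ in the substituents. In an ADME assay on BHK cells (Mesocricetus auratus) for cytotoxicity, read by MTT assay, with a stated time of 96 h (a higher number here means that more compound is tolerated, a lower number that less compound is tolerated), compound 1 gives only a limit, > 100000 nM. Compound 2 likewise gives only a limit, > 100000 nM. Compound 3 also gives only a limit, > 100000 nM. Going by the values given here, the single measured step, a step that the two limits leave unreadable from compound 1 to compound 2, stays unreadable because all three values sit at the limit of > 100000 nM in this assay, at which 3 of the 3 values shown sit. Compound 4 `O=C(CCl)Nc1ccc(-c2nc3cc(C(F)(F)F)ccc3[nH]2)cc1` differs from compound 2 by ((chloromethyl)carbonyl)amino in place of methoxy on an aromatic carbon. Among the compounds with values here, no measured step bears on this change, so no size can be read for it and compound 2 is only placed at the limit. Compound 4 is estimated at 60000 nM, within 10000 nM to 200000 nM. The expected step is an at least 1.6-fold lower number from compound 2 to compound 4 (0.22 log units; that floor lies within the scatter).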

Compound 4, half-maximal cytotoxic concentration: 22000 nM
Compound 4: middle estimate off by 2.7-fold (0.44 log units), on the high side; low and high end bracket the measured number.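

In this assay, ((chloromethyl)carbonyl)amino in place of methoxy on the aromatic carbon para to a large group gives an at least 4.5-fold lower number from compound 2 to compound 4 (0.65 log units; beyond the scatter). This step is only a floor, as compound 2 gives a limit. The position does respond to substitution, which the earlier compounds could not show, since all of them stay at the limit: the limit of > 100000 nM in this assay, at which 3 of the 4 values shown sit.

Going by these compounds, it remains open whether the step follows the chlorine or the amide. An acetylamino group without the chlorine, or a free amine at this place, would separate the two.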